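The source may hold more compounds than are shown below. What is called first, only, known or untested is meant among the compounds shown, and "the series" means these compounds.

Measured compounds:
- Compound 1 `Cc1cc(C)cc(S(=O)(=O)c2c(C(=O)Nc3cccc(O)c3)[nH]c3ccc(Cl)cc23)c1`: 24600 nM
- Compound 2 `Cc1cc(C)cc(S(=O)(=O)c2c(C(=O)NCc3ccc(O)cc3)[nH]c3ccc(Cl)cc23)c1`: 6250 nM

Among the measured compounds shown here, in an ADME assay on MT4 cells (Homo sapiens) for cytotoxicity, read by MTT assay (a higher number here means that more compound is tolerated, a lower number that less compound is tolerated), compound 2 gives 6250 nM, the lower of the two numbers so far. For the measured compounds named here, the only other measured compound, compound 1, gives 24600 nM.

The next compound, compound 3 `Cc1cc(C)cc(S(=O)(=O)c2c(C(=O)Nc3ccc(CO)cc3)[nH]c3ccc(Cl)cc23)c1`, has not yet been measured. It differs from compound 2 in one place, with 4-(hydroxymethyl)phenyl in place of 4-hydroxybenzyl on an amide-type nitrogen.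

Just one measured step bears on this change: a 3.9-fold lower number from compound 1 to compound 2 (0.60 log units; beyond the scatter). That step put 4-hydroxybenzyl in place of 3-hydroxyphenyl at the same nitrogen. Compound 3 returns to a phenyl group there, as in compound 1, although its group is not the 3-hydroxyphenyl of compound 1. A partial return toward the higher number is therefore reasonable, but a single step is thin support. The expected change in this assay is upward and smaller than the step just described. The estimated step is a 2.2-fold higher number from compound 2 to compound 3 (0.35 log units; beyond the scatter). For compound 3 the expected value is 14000 nM, with an estimated range from 5000 nM to 35000 nM.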

Compound 3, half-maximal cytotoxic concentration: 39600 nM
Compound 3: middle estimate off by 2.8-fold (0.45 log units), on the low side; measured number above the stated range.
By their numbers in this assay, from the lowest: compound 2; then compounds 1 and 3 (each within the scatter of the next).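

In this assay, exchanging 4-hydroxybenzyl for 4-(hydroxymethyl)phenyl on the amide-type nitrogen gives a 6.3-fold higher number from compound 2 to compound 3 (0.80 log units; beyond the scatter), even though the two groups have the same atoms and the same counts of hydrogen-bond donors and acceptors, so the way those atoms are joined matters at this position and a simple count of them does not predict the result. Replacing 3-hydroxyphenyl with 4-(hydroxymethyl)phenyl gives a 1.6-fold higher number from compound 1 to compound 3 (0.21 log units; within the scatter), which places the two compounds with substituted phenyl groups on this nitrogen together, while compound 2, the only one of the three with 4-hydroxybenzyl, stands apart with the lowest number. Nothing in the data shown explains this difference.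

As far as these compounds go, it remains open whether the lower number belongs to benzyl-type groups on this nitrogen in general or only to 4-hydroxybenzyl, and what part the hydroxyl plays in either case. Plain benzyl, plain phenyl and 3-hydroxybenzyl on the same nitrogen would help to separate these possibilities, and 4-(aminomethyl)phenyl would test whether an amine can stand in place of the hydroxyl of compound 3.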